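Urea analogues and a bromo-for-ethyl exchange

A few compounds are considered here, and "the series" means these few. Any claim that something is new, unique, unknown or untested is made for them only; others in the source may bear on it.

The compounds measured so far:
compound 1, `CCc1ccccc1NC(=O)N[C@H](C)c1ccccc1`, giving 100% in an ADME assay on the whole organism with Oryza sativa as the target, tested at 1 uM; on this read-out lower numbers stand for a stronger effect and higher numbers for a weaker effect at the one concentration tested
compound 2, `CCc1ccccc1NC(=O)N[C@@H](C)c1ccccc1`, giving 100% in this assay
compound 3, `CCc1cccc(NC(=O)N[C@H](C)c2ccccc2)c1`, giving 71% in this assay

Compound 2 stands level with compound 1, the two together at the top of the three numbers; compound 3 gives a number well below either. The only step between compounds that differ in one place is no change at the digits printed from compound 1 to compound 2 (within the scatter), and its two members are the same set of atoms and bonds in a different configuration, as shown by the fact that compounds 1 and 2 differ only in the configuration as drawn.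

Compound 4, `C[C@H](NC(=O)Nc1ccccc1Br)c1ccccc1`, has not yet been measured. It differs from compound 2 by bromo in place of ethyl on an aromatic carbon. Within the data shown here, no measured step exchanges one group for another on an aromatic carbon, so the stereo step alone does not bear on this change, and compound 3 offers only its own value next to that of compound 2. The account therefore expects compound 4 to stay near the top of the range, with room for a fall: it is estimated at 90%, between 60% and 100%, which is expected to mean a step of a number 10 percentage points lower from compound 2 to compound 4 (within the scatter).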

Compound 4, a percentage reported as activity, at one concentration (the size of the read-out at that concentration, not a potency): 99%
The estimate for compound 4 lay 9 percentage points below the measured number, and the stated range covers the measured number.
By their numbers in this assay, from the lowest: compound 3; then compounds 4, 1 and 2 (each within the scatter of the next).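

In this assay, among these compounds, the exchange of ethyl for bromo on an aromatic carbon, ortho to a large group, gives a number 1 percentage points lower from compound 2 to compound 4 (within the scatter); until now, the only step read between compounds differing in one place was a change of configuration. At this position, therefore, a group of 2 heavy atoms can give way to a bromine atom with no change in the number beyond the scatter, so this read-out does not distinguish ethyl from bromo here. Nothing on record gives a reason for this outcome or bears on the exchange itself.

The compounds shown do not say whether this tolerance extends to other groups at the same place, such as an amine, a carboxylic acid or a longer chain, since ethyl and bromo are the only two seen there. They also leave open whether bromo would behave the same way in the opposite configuration at the stereocentre, or at the place that the ethyl group occupies in compound 3, which gives 71%.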